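The compounds below may be only part of what the source reports. "The series", "measured", "known", "first", "only" and "open" are said of these compounds alone.

In the search for cytotoxic compounds in this series, a functional assay on UACC-62 cells (Homo sapiens) for cytotoxicity, read by MTT assay, with a stated time of 6 days (a lower number here means a stronger inhibitor, a higher number a weaker inhibitor), offers little to work from. Compound 1 `COc1ccccc1NC(=O)SC[C@H](NC(C)=O)C(=O)O` reads > 200000 nM, which is a limit of the assay and not a number. Among the compounds with values here, compound 2 `CC(=O)N[C@@H](CSC(=O)Nc1ccccc1)C(=O)O` gives 125000 nM, the only true number so far, so it has no measured neighbour to be ranked against.

Compound 3 `CSc1ccccc1NC(=O)SC[C@H](NC(C)=O)C(=O)O` follows from compound 2 with methylsulfanyl in place of hydrogen on an aromatic carbon, ortho to a large group (methylsulfanyl in place of hydrogen on an aromatic carbon).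

Within the data shown here, only one measured step bears on this change: an at least 1.6-fold lower number from compound 1 to compound 2 (0.20 log units; that floor lies within the scatter), with hydrogen in place of methoxy on an aromatic carbon. That step is a floor and not a firm size, so it gives weak guidance. It does involve the loss of a group from an aromatic carbon, whereas compound 3 gains one, so a modest move toward a higher number in this assay seems more likely than a gain in strength, and the move may not clear the scatter.

The expected change is a 1.4-fold higher number from compound 2 to compound 3 (0.13 log units; within the scatter). For compound 3 the estimated value is 170000 nM, with an expected range of 80000 nM to 320000 nM.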

Compound 3, half-maximal inhibitory concentration: > 200000 nM
Compound 3: a limit, no number; the forecaster's own chance of this, stated with the estimate: 45%; at least 1.1-fold (0.07 log units) between middle value and limit.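

In this assay, methylsulfanyl on the aromatic carbon ortho to a large group gives an at least 1.6-fold higher number from compound 2 to compound 3 (0.20 log units; that floor lies within the scatter), so this floor alone does not establish a real loss of strength. Compound 3 gives > 200000 nM, which is a limit of the assay and not a number. With this second group, the picture at this position is that compound 1 with methoxy and compound 3 with methylsulfanyl both end at a limit, while compound 2 with hydrogen keeps a number, and the size of any change cannot be read beyond the floor because the values stop at the same point: the limit of > 200000 nM in this assay, at which 2 of the 3 values shown sit.

The step between compound 1 and compound 3 cannot be read, since both values are limits, so methoxy and methylsulfanyl cannot be ranked against each other. The compounds shown leave open how far beyond the limit these two lie, and whether a different group at this position, such as an amine or a longer chain, would give a measurable number at all.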